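The compounds below may be only part of what the source reports. "The series", "measured", "known", "first", "only" and "open" are said of these compounds alone.

The compounds share one core, seen in compound 1 `Cc1cn([C@@H]2O[C@H](CO[Si](C)(C)C(C)(C)C)[C@@]3(OS(=O)(=O)C=C3NC(=O)c3ccccc3)[C@H]2O[Si](C)(C)C(C)(C)C)c(=O)n(C)c1=O` and in compound 2 `Cc1cn([C@@H]2O[C@H](CO[Si](C)(C)C(C)(C)C)[C@@]3(OS(=O)(=O)C=C3NCC(=O)C(=O)N3CCC3)[C@H]2O[Si](C)(C)C(C)(C)C)c(=O)n(C)c1=O`. In a functional assay on HEL cells (Homo sapiens) for cytotoxicity, read by microscopy (on this read-out lower numbers stand for higher toxicity in this test and higher numbers for lower toxicity in this test), compound 1 reaches only a limit of the assay, >= 3200 nM. In this assay, among the compounds with values here, compound 2 gives 65000 nM, which is the only number in the set. The step that the limit leaves unreadable from compound 1 to compound 2 cannot be sized because of the limit of >= 3200 nM in this assay, at which 1 of the 2 values shown sits. Compound 3 `COC(=O)NC1=CS(=O)(=O)O[C@@]12[C@@H](CO[Si](C)(C)C(C)(C)C)O[C@@H](n1cc(C)c(=O)n(C)c1=O)[C@@H]2O[Si](C)(C)C(C)(C)C` arises from compound 2 through the change (methoxycarbonyl in place of (((azetidin-1-yl)carbonyl)carbonyl)methyl on an amine nitrogen). Within the data shown here, no measured step bears on this change: the single step known, which swaps a benzoyl group, is left unreadable by the limit. The expectation for compound 3 therefore rests on compound 2 alone, and a step of no change at the digits printed from compound 2 to compound 3 (within the scatter) is estimated, meaning nothing beyond the scatter. Compound 3 is expected to give 65000 nM in this assay, within a range from 15000 nM to 250000 nM.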

Compound 3, minimum cytotoxic concentration: >= 50000 nM
Compound 3: only a limit was reported; the forecaster's own chance of this, stated with the estimate: 40%; the middle value is on the limit's open side.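

In this assay compound 3 gives >= 50000 nM as a limit of the assay, not a number. No new step can be read among compound 1, compound 2 and compound 3, because every pair includes a limit: the limit of >= 50000 nM in this assay, at which 1 of the 3 values shown sits.

The compounds shown leave open how far exchanging benzoyl, (((azetidin-1-yl)carbonyl)carbonyl)methyl and methoxycarbonyl on the amine nitrogen shifts the read-out.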